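Shortening the amide chain from compound 1 to compound 4

A few compounds are considered here, and "the series" means these few. Any claim that something is new, unique, unknown or untested is made for them only; others in the source may bear on it.

Compound 1 `CCCCC(=O)N(Cc1ccc(OC)c(O)c1)c1cc(OC)c(OC)c(OC)c1` is the tertiary amide bearing the butylcarbonyl chain. In a functional assay on KYSE-450 cells (Homo sapiens) for inhibition, read by MTT assay, with a stated time of 48 h (on this read-out lower numbers stand for stronger inhibition and higher numbers for weaker inhibition), compound 1 gives 300 nM, the lowest of the three numbers in hand. Compound 2 `C/C=C/C(=O)N(Cc1cc(OC)c(OC)c(OC)c1)c1ccc(OC)c(O)c1` gives 9160 nM in the same assay, and compound 3 `COc1ccc(CNc2cc(OC)c(OC)c(OC)c2)cc1Br` gives 39800 nM. Going by the values given here, both of these numbers lie beyond the scatter from compound 1, so compound 1 stands as the most potent of the three measured compounds; neither compound 2 nor compound 3 differs from it in one place only, so no single step between measured compounds is available for comparison.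

Compound 4 `CCC(=O)N(Cc1ccc(OC)c(O)c1)c1cc(OC)c(OC)c(OC)c1` differs from compound 1 by a single change: hydrogen in place of ethyl on a saturated chain carbon, two bonds along the chain from a carbonyl carbon. The shared core, the amide and the ring substituents stay the same; only the saturated chain beyond the carbonyl is cut. Among the compounds with values here, no measured pair in this set shows a step of this kind, so its size cannot be read from the data. The expectation is a small step, most likely a mild loss of inhibition, near or just beyond the scatter, estimated as a 1.8-fold higher number from compound 1 to compound 4 (0.26 log units; within the scatter). For compound 4 in this assay the estimate is 550 nM, with a range from 200 nM to 1600 nM.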

Compound 4, half-maximal inhibitory concentration: 98 nM
Compound 4: middle estimate off by 5.6-fold (0.75 log units), on the high side, and the stated range ends above it.
By their numbers in this assay, from the lowest: compound 4; then compound 1; then compound 2; then compound 3.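

In this assay, the saturated chain beyond the carbonyl proves to be a place where chain length counts: going from butylcarbonyl to propanoyl gives a 3.1-fold lower number from compound 1 to compound 4 (0.49 log units; beyond the scatter), a gain in inhibition beyond the scatter. Going by these compounds alone, the earlier compounds offered no one-place step, so this is the first direct reading of any single change, and it shows that the ethyl that leaves is not needed for inhibition at this level, with the shared core, the amide and the ring substituents unchanged. Nothing in hand accounts for the gain, so its cause stays unknown.

This single pair gives a direction for the chain but no optimum, and it supports no trend beyond these two compounds. From the compounds shown here alone, whether an acetyl group would extend the gain or reverse it stays open, as does the response to a branched chain such as isobutyryl or a ring-bearing acyl group such as cyclopropylcarbonyl in the same place.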